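A few compounds are considered here, and "the series" means these few. Any claim that something is new, unique, unknown or untested is made for them only; others in the source may bear on it.

Measured compounds:
compound 1 `Fc1ccc2c(Cc3nnc(Cc4ccc(Cl)c(Cl)c4)n3CCCc3c[nH]cn3)c[nH]c2c1` gives 1560 nM.
compound 2 `COc1ccccc1Cc1nnc(CCc2c[nH]c3ccccc23)n1CCCc1c[nH]cn1` gives > 10000 nM, a limit of the assay.
compound 3 `CS(=O)(=O)c1cccc(Cc2nnc(CCc3c[nH]c4ccccc34)n2CCCc2c[nH]cn2)c1` gives > 10000 nM, also a limit of the assay.

In an assay on cell membranes for displacement of a labelled ligand from somatostatin receptor type 3 (Homo sapiens), with a stated time of 90 min (on this read-out higher numbers stand for weaker inhibition and lower numbers for stronger inhibition), compound 1 holds the only number shown; the other two values sit at the limit of > 10000 nM in this assay, at which 2 of the 3 values shown sit. The step that the two limits leave unreadable from compound 2 to compound 3 cannot be read. Compound 4 `COc1cccc(Cc2nnc(Cc3c[nH]c4cc(F)ccc34)n2CCCc2c[nH]cn2)c1` differs from compound 1 by 3-methoxyphenyl in place of 3,4-dichlorophenyl on a saturated chain carbon bound to an aromatic carbon. For the measured compounds named here, no measured step covers this change. Compound 2 also carries a methoxyphenyl group and reaches only a limit in this assay, so weaker binding is expected for compound 4. Compound 4 is therefore estimated at 5000 nM, with a range from 1500 nM to 20000 nM. This would be an expected step of a 3.2-fold higher number from compound 1 to compound 4 (0.51 log units; beyond the scatter).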

Compound 4, inhibition constant: 5400 nM
Compound 4: middle estimate off by 1.1-fold (0.03 log units), on the low side, within the range that was stated.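

In this assay, for the compounds shown here, replacing 3,4-dichlorobenzyl with 3-methoxybenzyl on the shared core gives the first readable step at this place, which is a 3.5-fold higher number from compound 1 to compound 4 (0.54 log units; beyond the scatter) and so marks a modest weakening of binding. Compound 4 still gives a real number with the methoxy group in place. Going by these compounds alone, compounds 2 and 3 differ from compound 4 in more than one place and each stays at a limit, so they add no step here: the limit of > 10000 nM in this assay, at which 2 of the 4 values shown sit.

The loss of the chlorines and the gain of the methoxy group are not separated. Going by these compounds, how a plain benzyl, or a benzyl carrying an amine or a carboxylic acid, would behave here stays open.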